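This account rests on a few compounds, and the source may have more. Where it says the series, first, only, none or still open, it means among the compounds named here.

Compound 1 `COc1ccc(-c2cc(/C=C/C(=O)c3ccc(N)cc3)[nH]n2)cc1` is measured in a functional assay on OVCAR-8 cells (Homo sapiens) for inhibition, read by sulforhodamine B assay, with a stated time of 48 h (on this read-out lower numbers stand for higher toxicity in this test and higher numbers for lower toxicity in this test), only as a limit, > 100000 nM. Compound 2 `COc1ccc(C(=O)/C=C/c2cc(-c3cc(OC)c(OC)c(OC)c3)n[nH]2)cc1OC` gives 5640 nM in this assay. Compound 3 `COc1ccc(-c2cc(/C=C/C(=O)c3ccc(N)cc3)[nH]n2)cc1OC` gives 39000 nM in this assay.

Compound 3 differs from compound 1 by one change, (methoxy in place of hydrogen on an aromatic carbon), and this brought an at least 2.5-fold lower number from compound 1 to compound 3 (0.40 log units; beyond the scatter). How far the step really reaches is open because compound 1 sits at the limit of > 100000 nM in this assay, at which 1 of the 3 values shown sits. The difference between the core of compound 1 and the core of compound 2 is not broken down here.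

Compound 4 `COc1cc(C(=O)/C=C/c2cc(-c3cc(OC)c(OC)c(OC)c3)n[nH]2)cc(OC)c1OC` has not been measured. It differs from compound 2 by methoxy in place of hydrogen on an aromatic carbon, the same kind of change, but here the place is also meta to a methoxy group. The step from compound 1 to compound 3 suggests a lower number; compound 2 is expected to move to compound 4 by a 2.3-fold lower number from compound 2 to compound 4 (0.35 log units; beyond the scatter), giving an estimate of 2500 nM, within 600 nM to 10000 nM.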

Compound 4, concentration lethal to 50% of the cells: 6810 nM
Compound 4: the middle estimate sits 2.7-fold (0.44 log units) below what was measured, within the range that was stated.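

In this assay, methoxy in place of hydrogen on an aromatic carbon gave a 1.2-fold higher number from compound 2 to compound 4 (0.08 log units; within the scatter), so compound 2 and compound 4 cannot be told apart here. The same change therefore does not carry over from one core to the other with the same result: the same change on two cores in this assay, an at least 2.5-fold lower number (0.40 log units; beyond the scatter) from compound 1 to compound 3 and a 1.2-fold higher number (0.08 log units; within the scatter) from compound 2 to compound 4, at least 3.0-fold (0.49 log units) apart, beyond the scatter of two such steps Compound 1 is known only as a limit, so the full size of the earlier step stays unknown, and two pairs do not show why the cores differ: the limit of > 100000 nM in this assay, at which 1 of the 4 values shown sits.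

The compounds shown leave open what an ethoxy group, a fluorine atom or a carboxylic acid would do in place of that methoxy. They also leave open how the methoxy change would behave on a third core.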